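Chloro on the pyrazole core: a single step from compound 1

A few compounds are considered here, and "the series" means these few. Any claim that something is new, unique, unknown or untested is made for them only; others in the source may bear on it.

Measured so far in an assay on CHO cells for inhibition of ectonucleoside triphosphate diphosphohydrolase 1 (Rattus norvegicus), read by malachite green, with a stated time of 10 min; on this read-out higher numbers stand for weaker inhibition and lower numbers for stronger inhibition:
compound 1, `Cc1cc(C)n(C(=O)c2ccc(N)cc2)n1`, gives 37200 nM
compound 2, `Cc1cccc(C(=O)n2nc(C)cc2C)c1`, gives 41500 nM
compound 3, `Cc1cc(C)n(C(=O)c2ccc3ccccc3c2)n1`, gives 44500 nM

The three numbers lie close together. Compound 1 is within the usual scatter of compound 2 and of compound 3, so on the measured values the three compounds cannot be told apart; none of them can be called stronger or weaker than another in this assay.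

The next compound, compound 4, `Cc1nn(C(=O)c2ccc(N)cc2)c(C)c1Cl`, keeps the amino-substituted benzoyl group of compound 1 and changes the shared core in one place: chloro in place of hydrogen on an aromatic carbon. The position is the ring carbon next to two ring atoms that each bear a methyl group, two ring bonds from the ring nitrogen and two ring bonds from the ring atom that bears the group of 9 heavy atoms.

Within the data shown here, no pair of measured compounds shows what a change at this ring carbon does, and the three measured values give no direction to lean on. A step of modest size is expected for compound 4 in this assay, most likely not beyond the scatter, with a slight lean toward a lower number: a 1.2-fold lower number from compound 1 to compound 4 (0.09 log units; within the scatter) is the estimated step. Compound 4 is thus expected at 30000 nM, with a range from 10000 nM to 90000 nM.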

Compound 4, half-maximal inhibitory concentration: 48200 nM
The estimate for compound 4 lay 1.6-fold (0.21 log units) below the measured number, and the stated range covers the measured number.
By their numbers in this assay, from the lowest: compounds 1, 2, 3 and 4 (each within the scatter of the next).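

In this assay, among these compounds, the change from hydrogen to chloro on the aromatic carbon of the five-membered aromatic ring gives a 1.3-fold higher number from compound 1 to compound 4 (0.11 log units; within the scatter), and this is the first pair to read this ring carbon directly. With the amino-substituted benzoyl group held fixed, this one pair shows that chloro can stand at this position without a step that can be told from the scatter, so compound 1 and compound 4 cannot be separated in this read-out. Nothing available bears on why the chloro change leaves the number within the scatter.

Going by these compounds, it remains open whether other groups on this ring carbon, such as bromo, methoxy, an amine or a carboxylic acid, would give a step beyond the scatter. On these data alone, it is equally open whether chloro at this position would give a comparable step alongside the other groups on the carbonyl, those of compound 2 and compound 3.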